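The compounds below may be only part of what the source reports. "The series", "measured", "known", "first", "only" and "open" are said of these compounds alone.

Compound 3 `COc1cc(Cl)cc(-c2nn(-c3cccc(NC(=O)Nc4ccc(Cl)c(Cl)c4)c3)cc2-c2ccncc2)c1` stands highest of the three numbers measured in a functional assay on K562 cells (Homo sapiens) for inhibition, read by sulforhodamine B assay, with a stated time of 48 h, tested at 100 uM; a higher number here means a weaker effect of the compound at the concentration tested, a lower number a stronger effect: compound 3 gives 3%, while compound 1 `COc1cc(Cl)cc(-c2nn(-c3cccc(NC(=O)Nc4ccc(Cl)c(C(F)(F)F)c4)c3)cc2-c2ccncc2)c1` gives -51% and compound 2 `COc1cc(Cl)cc(-c2nn(-c3cccc(NC(=O)Nc4cc(C(F)(F)F)cc(C(F)(F)F)c4)c3)cc2-c2ccncc2)c1` gives -42%. Compound 4 `COc1cc(Cl)cc(-c2nn(-c3cccc(NC(=O)Nc4cccc(C(F)(F)F)c4)c3)cc2-c2ccncc2)c1` has not yet been measured. It differs from compound 3 in one place: 3-(trifluoromethyl)phenyl in place of 3,4-dichlorophenyl on an amide-type nitrogen.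

Among the compounds with values here, one measured step bears on this change. Going a number 54 percentage points higher from compound 1 to compound 3 (beyond the scatter), the number rose sharply when chloro replaced trifluoromethyl on an aromatic carbon. Compound 4 carries a trifluoromethyl group again, as compound 1 and compound 2 do, and both of those gave numbers far below compound 3. Within the data shown here, the change into compound 4 also removes a second chloro, for which no separate step exists, so the size of the move is less certain than its direction. A fall beyond the scatter is therefore expected, with compound 4 estimated at -25%, in the range -60% to 10%, a step of a number 28 percentage points lower from compound 3 to compound 4 (beyond the scatter).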

Compound 4, a percentage reported as activity, at one concentration (the size of the read-out at that concentration, not a potency): -22%
Beside the measured number, compound 4's estimate is 3 percentage points below it; measured number inside the range.
By their numbers in this assay, from the lowest: compounds 1 and 2 (each within the scatter of the next); then compound 4; then compound 3.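

In this assay, a single trifluoromethyl group on the phenyl ring on the amide-type nitrogen is enough to give a clear fall when it replaces the two chloro groups, with a number 25 percentage points lower from compound 3 to compound 4 (beyond the scatter) in the new comparison. That lone group does not match the rings with a second group, however: removing the second trifluoromethyl gives a number 20 percentage points higher from compound 2 to compound 4 (beyond the scatter) and removing the chloro gives a number 29 percentage points higher from compound 1 to compound 4 (beyond the scatter) as both changes raise the number, so among these three compounds a second group of either kind goes with a stronger effect. Nothing measured here explains these shifts.

From the compounds shown here alone, whether a lone chloro, a methoxy group, a nitrile or a carboxylic acid on that ring would act like the lone trifluoromethyl remains open. So does how a bare phenyl ring would compare, since all four compounds carry at least one group there.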